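Methyl for phenyl on the saturated ring of compound 2

The source may hold more compounds than are shown below. What is called first, only, known or untested is meant among the compounds shown, and "the series" means these compounds.

Measured so far:
compound 1 `C=C(C)C(=O)c1ccc(OC)cc1OC` — 32.3%
compound 2 `COc1ccc(C2=NN(C(=O)NS(=O)(=O)c3ccc(Cl)cc3)CC2c2ccccc2)c(OC)c1` — 23.6%

In a functional assay on the whole organism (strain albino) for inhibition, with Rattus norvegicus as the target, read by paw edema, with stated times of 30 min and 4 h, at a dose of 25 mg/kg by the intraperitoneal route (a higher number here means more inhibition at the dose given (going by the name of the read-out), a lower number less inhibition), compound 1 gives 32.3% and compound 2 gives 23.6%; the two values lie within the usual scatter of each other, so compound 2 cannot be placed apart from compound 1.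

Compound 3 `COc1ccc(C2=NN(C(=O)NS(=O)(=O)c3ccc(Cl)cc3)CC2C)c(OC)c1` is not yet measured. The change from compound 2 is methyl in place of phenyl on a saturated ring carbon. Among the measured compounds shown here, no measured pair shows this change, so the expected step from compound 2 to compound 3 in this assay is taken as none beyond the scatter, with a slight lean downward: a number 3.6 percentage points lower from compound 2 to compound 3 (within the scatter). Compound 3 is accordingly expected to give 20%, within the range 8% to 34%.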

Compound 3, a percentage reported as inhibition, in the whole organism at one dose (the size of the read-out at that dose, not a potency): 18.8%
Compound 3: the middle estimate sits 1.2 percentage points above what was measured; the measured number falls inside the stated range.
By their numbers in this assay, from the lowest: compounds 3, 2 and 1 (each within the scatter of the next, the first and the last beyond it).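

In this assay methyl in place of phenyl on the saturated ring carbon gives a number 4.8 percentage points lower from compound 2 to compound 3 (within the scatter) and so does not separate the two compounds. At this position, a single carbon and a six-membered aromatic ring of carbon only therefore give numbers that cannot be told apart at this dose. Nothing available explains this result.

On these data alone, whether an amine, a carboxylic acid or a longer chain on this carbon would give a number beyond the scatter from compound 2 remains open. So does the outcome of replacing the 4-chlorophenyl group on the sulfonyl with another group.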